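The source may report more compounds than this note shows. Statements on the series, on what has been measured and on what is new or still open speak of the compounds shown alone.

Compound 1 (`COc1ccc2c(/C=C/C(=O)c3cc(N)c(OC)c(OC)c3)cn(C)c2c1`) gives 505 nM
Compound 2 (`COc1ccc2c(/C=C(\C)C(=O)c3cc(OC)c(OC)c([Se]C)c3)cn(C)c2c1`) gives 44 nM

Among the measured compounds shown here, both numbers come from a functional assay on MCF7 cells (Homo sapiens) for antiproliferative activity, read by MTT assay, with a stated time of 48 h (on this read-out lower numbers stand for stronger inhibition and higher numbers for weaker inhibition), and stand for the only two measured compounds in this account. Compound 2 has the lower number of the pair, and its gap to compound 1 lies beyond the usual scatter of repeated measurements. The two compounds differ in more than one place, so their gap cannot be assigned to any single structural feature.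

The next compound, compound 3 (`COc1ccc2c(/C=C(\C)C(=O)c3cc(OC)c(OC)c([Se]C)c3)c[nH]c2c1`), departs from compound 2 in one place only, with hydrogen in place of methyl on an aromatic nitrogen. For the measured compounds named here, no measured pair shows what this change does in this assay and the expectation is therefore held loosely. Compound 2 (44 nM) serves as the anchor, and a small weakening no larger than the scatter is expected, although a shift in the other direction cannot be ruled out. The estimated step is a 1.6-fold higher number from compound 2 to compound 3 (0.20 log units; within the scatter) (an expectation, not a measurement). Compound 3 is estimated at 70 nM (expected range 20 nM to 250 nM).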

Compound 3, half-maximal inhibitory concentration: 35 nM
Compound 3: the middle estimate sits 2.0-fold (0.30 log units) above what was measured, within the range that was stated.
By their numbers in this assay, from the lowest: compounds 3 and 2 (each within the scatter of the next); then compound 1.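

In this assay, among the compounds shown here, the swap of methyl for hydrogen on the aromatic nitrogen gives a 1.3-fold lower number from compound 2 to compound 3 (0.10 log units; within the scatter) and is the first change in this account that can be read on its own, since compound 1 and compound 2 differ in more than one place. Within this single pair, the methyl on that nitrogen is therefore not needed for a number in the range of compound 2, and compound 3 with its hydrogen cannot be told apart from compound 2 at this position. No supporting measurement is available to explain why the two compounds read alike.

What the compounds shown leave open is how far this tolerance extends, since methyl and hydrogen are the only two substituents seen on this nitrogen, and an ethyl group, an acetyl group or a longer chain carrying an amine could give a quite different number. As far as these compounds go, it also remains open whether the same swap would read the same way on the core of compound 1, with its amine and without the methylselanyl group.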